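The compounds below may be only part of what the source reports. "The series", "measured", "known", "first", "only" and "open" are said of these compounds alone.

In a functional assay on HeLa cells (Homo sapiens) for cytotoxicity, read by WST assay, with a stated time of 48 h (on this read-out higher numbers stand for weaker inhibition and lower numbers for stronger inhibition), compound 1 `COc1cc(C(c2ccc(O)c(OC)c2)[C@@H](C)[C@@H](C)CF)ccc1O` gives 42000 nM and compound 2 `COC[C@@H](C(C)C)C(c1ccc(O)c(OC)c1)c1ccc(O)c(OC)c1` gives 69000 nM, so compound 2 stands level with compound 1 within the scatter. Compound 3 `COc1cc(C(c2ccc(O)c(OC)c2)[C@@H](C)[C@H](C)CO)ccc1O` differs from compound 2 by 2-(hydroxymethyl)-1-methylpropyl in place of 1-(methoxymethyl)-2-methylpropyl on a saturated chain carbon bound to two aromatic carbons. Going by the values given here, the only measured step in this chain is small, a 1.6-fold higher number from compound 1 to compound 2 (0.22 log units; within the scatter), so no step beyond the scatter is expected in this assay. The expected step is a 1.5-fold lower number from compound 2 to compound 3 (0.19 log units; within the scatter). For compound 3 the estimated value is 45000 nM, with a range of 18000 nM to 100000 nM.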

Compound 3, half-maximal inhibitory concentration: > 100000 nM
Compound 3: a limit, no number (the forecaster's own chance of this, stated with the estimate: 15%); middle value at least 2.2-fold (0.34 log units) away from the limit.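

In this assay compound 3 gives a limit and not a number: the limit of > 100000 nM in this assay, at which 1 of the 3 values shown sits. With 1-(hydroxymethyl)ethyl in place of 1-(fluoromethyl)ethyl on a saturated chain carbon bound to two saturated chain carbons, the series shows its first step beyond the scatter, an at least 2.3-fold higher number from compound 1 to compound 3 (0.37 log units; beyond the scatter). The change from 1-(methoxymethyl)-2-methylpropyl gives an at least 1.4-fold higher number from compound 2 to compound 3 (0.16 log units; that floor lies within the scatter), so this floor alone does not separate that pair.

Still open, as far as these compounds go, is where compound 3 would read as a number past its limit. Also open, from the compounds shown here alone, is how an amine or a carboxylic acid at this chain end would read in this assay.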